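Swapping the Aryl Arm of Compound 1

A few compounds are considered here, and "the series" means these few. Any claim that something is new, unique, unknown or untested is made for them only; others in the source may bear on it.

Compound 1 `O=C(O)Cc1sc(C(c2ccc(F)cc2)c2ccc(F)cc2)nc1-c1ccnc(F)c1` is examined in an in vitro assay on HEK385-7 cells for displacement of a labelled ligand from prostaglandin D2 receptor 2 (Homo sapiens) (a lower number here means a stronger inhibitor, a higher number a weaker inhibitor), where compound 1 gives 0.48 nM, the lowest of the two numbers in hand. Compound 2 `O=C(O)Cc1sc(C(c2ccccc2)c2ccccc2)nc1-c1ccc(C(F)(F)F)cc1` differs from it in more than one place, and in this assay compound 2 gives 1100 nM. Compound 3 `NS(=O)(=O)c1ccc(-c2nc(C(c3ccc(F)cc3)c3ccc(F)cc3)sc2CC(=O)O)cc1` has not been measured; it differs from compound 1 by 4-sulfamoylphenyl in place of 2-fluoropyridin-4-yl on an aromatic carbon. Within the data shown here, no single-change step is known to guide this, so the outcome is uncertain, but a modest loss is expected, a step of a 4.2-fold higher number from compound 1 to compound 3 (0.62 log units; beyond the scatter) that is expected to lie beyond the scatter. Compound 3 is therefore expected to give about 2 nM, within 0.5 nM to 10 nM.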

Compound 3, half-maximal inhibitory concentration: 1500 nM
Beside the measured number, compound 3's estimate is 750-fold (2.88 log units) below it; measured number outside the range, above it.
By their numbers in this assay, from the lowest: compound 1; then compounds 2 and 3 (each within the scatter of the next).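

On the aromatic carbon next to the ring nitrogen, the arm proves decisive: 4-sulfamoylphenyl in place of 2-fluoropyridin-4-yl gives a 3100-fold higher number from compound 1 to compound 3 (3.49 log units; beyond the scatter) in this assay with the rest of compound 1 unchanged. This is the only single-place step shown at this position, which compound 2 could not supply. Nothing measured here bears on the reason for the loss.

The step changes the ring and its substituent together, and the compounds shown do not separate the two. As far as these compounds go, whether a plain phenyl or a 4-fluorophenyl arm would hold the potency of compound 1 stays open.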